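Chloropyridyl for cyclopropylfuranyl on the shared core

The compounds below may be only part of what the source reports. "The series", "measured", "known", "first", "only" and "open" are said of these compounds alone.

For the measured compounds named here, compound 1 `Nc1nc(-c2ccc(C3CC3)o2)nc2sc(Cc3ccccc3)cc12` is the one member of the series with a measured number in a functional assay on CHO-K1 cells for antagonist activity at adenosine receptor A1 (Homo sapiens), read by a beta-galactosidase reporter and cAMP accumulation, with stated times of 15 min and 6 h (a higher number here means a weaker inhibitor, a lower number a stronger inhibitor), where compound 1 gives 861 nM. Compound 2 `Cc1csc(-c2nc(N)c3cc(C4(c5ccccc5)CC4)sc3n2)n1` is reported in this assay only as a limit, > 610 nM, not as a number; it sits at the limit of > 610 nM in this assay, at which 1 of the 2 values shown sits. Compound 3 `Nc1nc(-c2cccc(Cl)n2)nc2sc(Cc3ccccc3)cc12` carries 6-chloropyridin-2-yl in place of 5-cyclopropylfuran-2-yl on an aromatic carbon. Going by the values given here, no measured step between two compounds is available, so the size of this change is unknown; a modest loss, or none beyond the scatter, is expected. Compound 3 is estimated at 1500 nM, between 500 nM and 5000 nM. For compound 3 this means an expected step of a 1.7-fold higher number from compound 1 to compound 3 (0.24 log units; within the scatter) in this assay.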

Compound 3, inhibition constant: > 1000 nM
Compound 3 gave a limit, no number (the forecaster's own chance of this, stated with the estimate: 30%); the middle value is on the limit's open side.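

For the compounds shown here, at this aromatic carbon of the shared core, 6-chloropyridin-2-yl in place of 5-cyclopropylfuran-2-yl gives the first step in this assay with an at least 1.1-fold higher number from compound 1 to compound 3 (0.06 log units; that floor lies within the scatter) as its only reading. Compound 3 stands as a limit, not a number: the limit of > 1000 nM in this assay, at which 1 of the 3 values shown sits. The step is thus only a floor, and a loss beyond the scatter is neither shown nor excluded.

Whether the chlorine or the change of ring accounts for the step stays open. Unsubstituted pyridin-2-yl and 5-methylfuran-2-yl at this position would help separate the two.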